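The source may report more compounds than this note shows. Statements on the series, on what has been measured and on what is new or still open speak of the compounds shown alone.

Compound 3 `Brc1ccc(-c2cc(CN(c3ncccn3)c3nc4ccccc4s3)on2)cc1` sits within the scatter of the other two measured compounds: in a functional assay on COLO 205 cells (Homo sapiens) for antiproliferative activity, read by MTT assay (on this read-out lower numbers stand for stronger inhibition and higher numbers for weaker inhibition), compound 3 gives 8820 nM, while compound 1 `FC(F)(F)Sc1ccc(-c2cc(CN(c3ncccn3)c3nc4ccccc4s3)on2)cc1` gives 10100 nM and compound 2 `COc1ccc(-c2cc(CN(c3ncccn3)c3nc4ccccc4s3)on2)cc1` gives 5040 nM. Compound 4 `Fc1ccccc1-c1cc(CN(c2ncccn2)c2nc3ccccc3s2)on1` carries 2-fluorophenyl in place of 4-bromophenyl on an aromatic carbon. For the measured compounds named here, the steps that bear on this change are a 1.1-fold lower number from compound 1 to compound 3 (0.06 log units; within the scatter) and a 1.8-fold higher number from compound 2 to compound 3 (0.24 log units; within the scatter), both exchanges of the substituent on that phenyl ring, and neither rose above the scatter. On that record the step of a 1.1-fold lower number from compound 3 to compound 4 (0.04 log units; within the scatter) is expected to stay within the scatter as well, with no clear direction in this assay. Compound 4 is therefore estimated at 8000 nM, with a range from 3000 nM to 22000 nM.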

Compound 4, half-maximal inhibitory concentration: 13200 nM
Compound 4: the middle estimate sits 1.7-fold (0.22 log units) below what was measured; the measured number falls inside the stated range.
By their numbers in this assay, from the lowest: compounds 2, 3, 1 and 4 (each within the scatter of the next, the first and the last beyond it).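

In this assay, for the compounds shown here, 2-fluorophenyl gives the only step at this position that lies beyond the scatter, a 2.6-fold higher number from compound 2 to compound 4 (0.42 log units; beyond the scatter), while a 1.5-fold higher number from compound 3 to compound 4 (0.18 log units; within the scatter) and a 1.3-fold higher number from compound 1 to compound 4 (0.12 log units; within the scatter) both remain within it. The aryl group on this carbon can therefore shift the number, but the one separation shown is modest and involves only the 4-methoxyphenyl and 2-fluorophenyl groups. Nothing available explains that separation. Still open, on these data alone, is whether 4-fluorophenyl would read like 2-fluorophenyl, which would separate the fluoro group from its place on the ring. Also open, as far as these compounds go, is whether an amine or a carboxylic acid on that phenyl ring would move the number further.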